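Replacing a Substituted Phenyl Ring with a Benzyloxy Group

The source may report more compounds than this note shows. Statements on the series, on what has been measured and on what is new or still open speak of the compounds shown alone.

Compound 1 `COc1ccc(F)c(-c2ccc(S(=O)(=O)Nc3cc(N4C[C@@H](C)N[C@@H](C)C4)ccc3OC)cc2)c1` stands highest of the two compounds measured in a functional assay for agonist activity at growth hormone secretagogue receptor type 1 (Homo sapiens), read by FLIPR (on this read-out higher numbers stand for larger maximal responses and lower numbers for smaller maximal responses), giving 1.2. Its nearest neighbour is compound 2 `COc1ccc(N2C[C@@H](C)N[C@@H](C)C2)cc1NS(=O)(=O)c1cccc(-c2ccccc2)c1`, which in this assay gives 1, a gap beyond the usual scatter. Compound 3 `COc1ccc(N2C[C@@H](C)N[C@@H](C)C2)cc1NS(=O)(=O)c1ccc(OCc2ccccc2)cc1` has not yet been measured; it differs from compound 1 in one place: benzyloxy in place of 2-fluoro-5-methoxyphenyl on an aromatic carbon. Within the data shown here, no measured pair isolates this kind of change, so the step is expected to be a small decrease, near the scatter, a number 0.20 lower from compound 1 to compound 3 (beyond the scatter). Compound 3 is therefore estimated to give 1 in this assay , between 0.7 and 1.3.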

Compound 3, intrinsic activity: the largest response reached, as a fraction of the reference agonist's: 0.8
Compound 3: the middle estimate sits 0.20 above what was measured; the range from low to high includes it.
By their numbers in this assay, from the lowest: compound 3; then compound 2; then compound 1.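

Set on an aromatic carbon para to a large group, benzyloxy in place of 2-fluoro-5-methoxyphenyl lowers the maximal response in this assay by a number 0.40 lower from compound 1 to compound 3 (beyond the scatter) and so shows that this position does not tolerate every aromatic group equally. Both groups hold one six-membered aromatic ring of carbon only and one hydrogen-bond acceptor, so these shared counts do not preserve the response. Nothing available explains the drop. The compounds shown leave open whether the fluorine, the methoxy or the benzyloxy oxygen carries the step. As far as these compounds go, how an amine or a carboxylic acid at this position would fare also remains open.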